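Swapping the Ester Side Chain: Compound 3 to Compound 4

A few compounds are considered here, and "the series" means these few. Any claim that something is new, unique, unknown or untested is made for them only; others in the source may bear on it.

Three measured compounds share one core and differ only in the group on a saturated chain carbon bound to an oxygen next to a carbonyl group. In a functional assay on HEK293 cells for antagonist activity at Voltage-dependent L-type calcium channel subunit alpha-1D (Rattus norvegicus), read by FLIPR (on this read-out higher numbers stand for weaker inhibition and lower numbers for stronger inhibition), compound 1 `C#CCCOC(=O)C1=C(C)NC(C)=C(C(=O)OC)C1c1cccc([N+](=O)[O-])c1` gives 35 nM, compound 2 `COC(=O)C1=C(C)NC(C)=C(C(=O)OCC2CC2)C1c1cccc([N+](=O)[O-])c1` gives 21 nM and compound 3 `COC(=O)C1=C(C)NC(C)=C(C(=O)OCc2ccc(F)c(F)c2)C1c1cccc([N+](=O)[O-])c1` gives 20 nM. Compound 3 shows the lowest of the three numbers, yet the steps of a 1.8-fold lower number from compound 1 to compound 3 (0.24 log units; within the scatter) and a 1.1-fold lower number from compound 2 to compound 3 (0.02 log units; within the scatter) both lie within the scatter, as does a 1.7-fold lower number from compound 1 to compound 2 (0.22 log units; within the scatter). Compound 4 `COC(=O)C1=C(C)NC(C)=C(C(=O)OCCc2ccc(Cl)cc2)C1c1cccc([N+](=O)[O-])c1` differs from compound 3 by 4-chlorobenzyl in place of 3,4-difluorophenyl on a saturated chain carbon bound to an oxygen next to a carbonyl group. The earlier exchanges at this position moved the number only within the scatter, so the step of a 1.1-fold higher number from compound 3 to compound 4 (0.04 log units; within the scatter) in this assay is expected to be no larger. Compound 4 is therefore estimated at 22 nM, with a range from 10 nM to 50 nM.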

Compound 4, half-maximal inhibitory concentration: 39 nM
Estimate against measurement, compound 4: 1.8-fold (0.25 log units) below, within the range that was stated.
By their numbers in this assay, from the lowest: compounds 3, 2, 1 and 4 (each within the scatter of the next).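

With a 4-chlorophenyl ring carried on a two-carbon ethyl link, the position still shows no step beyond the scatter in this assay: the set now holds a 2.0-fold higher number from compound 3 to compound 4 (0.29 log units; within the scatter) and a 1.9-fold higher number from compound 2 to compound 4 (0.27 log units; within the scatter) as well as a 1.1-fold higher number from compound 1 to compound 4 (0.05 log units; within the scatter) among its steps. All four side chains, with or without an aromatic ring, therefore give numbers that the scatter does not separate along these steps. Nothing available here explains this result. Going by these compounds, whether an amine or a carboxylic acid on this chain, or a longer chain, would also stay within the scatter remains open.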